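This account rests on a few compounds, and the source may have more. Where it says the series, first, only, none or still open, it means among the compounds named here.

The shared core is seen in compound 1, `O=C(CN1CCN(c2ccccc2)CC1)Nc1nc2ccccc2[nH]1`, which in a functional assay, read by spectrophotometry, with a stated time of 30 min, tested at 150 ug/mL (on this read-out higher numbers stand for a stronger effect at the one concentration tested and lower numbers for a weaker effect), gives 40.6%. Compound 2, `O=C(CN1CCN(c2ccccc2F)CC1)Nc1nc2ccccc2[nH]1`, gives 56.6%, and compound 3, `O=C(CN1CCN(c2ncccn2)CC1)Nc1nc2ccccc2[nH]1`, gives 68.4%. On these three numbers compound 2 stands second highest: the nearest number is that of compound 3, the furthest that of compound 1, and both gaps are printed as beyond the scatter, a number 16 percentage points higher from compound 1 to compound 2 (beyond the scatter) and a number 11.8 percentage points higher from compound 2 to compound 3 (beyond the scatter).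

Compound 4, `O=C(CN1CCN(c2ccc([N+](=O)[O-])cc2)CC1)Nc1nc2ccccc2[nH]1`, is the next compound and has not yet been measured. It differs from compound 2 in one place: 4-nitrophenyl in place of 2-fluorophenyl on an amine nitrogen in a ring.

Within the data shown here, no measured step exchanges one substituted phenyl for another on this ring nitrogen. Among the measured compounds shown here, the steps that bear on it do so only loosely: from compound 1 to compound 2, a number 16 percentage points higher from compound 1 to compound 2 (beyond the scatter), and from compound 1 to compound 3, a number 27.8 percentage points higher from compound 1 to compound 3 (beyond the scatter), both modest and both upward when the plain phenyl is altered. Whether a 4-nitrophenyl behaves like a 2-fluorophenyl cannot be read from these three compounds, so only a small step in either direction, or none beyond the scatter, is expected: the step from compound 2 to compound 4 is estimated as a number 6.6 percentage points lower from compound 2 to compound 4 (within the scatter). For compound 4 the expected value is 50%, with a range from 30% to 70%.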

Compound 4, a percentage reported as activity, at one concentration (the size of the read-out at that concentration, not a potency): 64.9%
Compound 4: middle estimate off by 14.9 percentage points, on the low side, within the range that was stated.
By their numbers in this assay, from the lowest: compound 1; then compounds 2, 4 and 3 (each within the scatter of the next, the first and the last beyond it).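

In this assay, 4-nitrophenyl on the ring nitrogen gives a number 24.3 percentage points higher from compound 1 to compound 4 (beyond the scatter) and so becomes a second substituted phenyl set apart from the plain phenyl, alongside the 2-fluorophenyl of compound 2; among these compounds, nothing goes against the upward direction of replacing the plain phenyl. The substituted phenyls themselves cannot be told apart, as exchanging 2-fluorophenyl for 4-nitrophenyl gives a number 8.3 percentage points higher from compound 2 to compound 4 (within the scatter) and exchanging pyrimidin-2-yl for 4-nitrophenyl gives a number 3.5 percentage points lower from compound 3 to compound 4 (within the scatter) in this series. Compound 4 thus lies within the scatter of both compound 2 and compound 3, even though those two are separated beyond it, so the only clear division at this position is between compound 1, the lowest of the four, and the rest.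

Nothing available explains why these numbers fall as they do. Still open, as far as these compounds go, is whether the fluoro or nitro group itself or the place it occupies on the phenyl matters, since these two groups differ in both, and whether an amine or a carboxylic acid in place of the nitro would keep the number clear of compound 1.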